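The source may hold more compounds than are shown below. What is called first, only, known or untested is meant among the compounds shown, and "the series" means these compounds.

Measured so far in a functional assay on A-375 cells (Homo sapiens) for cytotoxicity, read by MTT assay, with a stated time of 72 h, tested at 10 uM; a lower number here means less inhibition of growth, a higher number more inhibition of growth at the concentration tested:
compound 1 `Cc1cccc(/C(N)=N/NC(=S)N2CCN(c3ccccn3)CC2)n1` gives 63.3%;
compound 2 `N/C(=N\NC(=S)N1CCCC1)c1ccc(F)cn1` gives 82.3%;
compound 3 `Cc1ccnc(/C(N)=N/NC(=S)N2CCSCC2)c1` gives 74.5%.

Compound 2 has the highest of these three numbers. Compound 3 comes nearest, and that gap lies within the usual scatter, so the two cannot be told apart. Compound 1 lies furthest away, and that gap is beyond the scatter. Compound 4 `N/C(=N\NC(=S)N1CCSCC1)c1ccc(F)cn1` differs from compound 2 in one place: thiomorpholin-4-yl in place of pyrrolidin-1-yl on a thiocarbonyl carbon. Among the measured compounds shown here, no measured pair shows this exchange on its own, so its effect is unknown. Compound 3 carries the same thiomorpholin-4-yl group and sits close to compound 2, which suggests only a small step. The expected change is a number 6.3 percentage points lower from compound 2 to compound 4 (within the scatter), a step not beyond the scatter. Compound 4 is therefore expected to give 76%, with a range from 60% to 88%.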

Compound 4, percent growth inhibition at one concentration: 70.9%
Compound 4: middle estimate off by 5.1 percentage points, on the high side, within the range that was stated.
By their numbers in this assay, from the lowest: compounds 1, 4, 3 and 2 (each within the scatter of the next, the first and the last beyond it).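

In this assay, among the compounds shown here, the exchange of pyrrolidin-1-yl for thiomorpholin-4-yl on a thiocarbonyl carbon gives a number 11.4 percentage points lower from compound 2 to compound 4 (beyond the scatter) and is the first change seen on its own, with the rest of the molecule held constant. The earlier compounds shown here differ in more than one place, so they could not show that this group alone moves the number by a modest step. Nothing available explains why this step occurs.

As far as these compounds go, it remains open whether the exchange has the same effect on another core. From the compounds shown here alone, how morpholin-4-yl or a dimethylamino group would compare at this thiocarbonyl carbon also remains open.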